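A few compounds are considered here, and "the series" means these few. Any claim that something is new, unique, unknown or untested is made for them only; others in the source may bear on it.

Measured so far:
compound 1 `Cc1cccc(C(=O)Nc2cccc(/C=C/C(=O)c3nc4ccccc4[nH]3)c2)c1`: 1420 nM
compound 2 `Cc1cc(C)cc(C(=O)Nc2cccc(/C=C/C(=O)c3nc4ccccc4[nH]3)c2)c1`: 1550 nM

Both numbers come from a functional assay on HCT-116 cells (Homo sapiens) for antiproliferative activity, read by MTT assay, with a stated time of 48 h; a lower number here means a stronger inhibitor, a higher number a weaker inhibitor. Going by the values given here, the only step measured, a 1.1-fold higher number from compound 1 to compound 2 (0.04 log units; within the scatter), shows compound 2 and compound 1 lying within the scatter of each other, so neither can be called the stronger. Compound 3 `Cc1ccccc1S(=O)(=O)Nc1cccc(/C=C/C(=O)c2nc3ccccc3[nH]2)c1` carries (2-methylphenyl)sulfonyl in place of (3,5-dimethylphenyl)carbonyl on a nitrogen on an aromatic ring. Among the compounds with values here, the single measured step concerns a methyl swap on a different part of the molecule, so it says little about this change. Compound 3 is therefore expected near compound 2, with a wide range: 2500 nM, between 800 nM and 8000 nM, meaning an expected step of a 1.6-fold higher number from compound 2 to compound 3 (0.21 log units; within the scatter).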

Compound 3, half-maximal inhibitory concentration: 955 nM
Compound 3: middle estimate off by 2.6-fold (0.42 log units), on the high side; low and high end bracket the measured number.
By their numbers in this assay, from the lowest: compounds 3, 1 and 2 (each within the scatter of the next).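

On the nitrogen on an aromatic ring, (2-methylphenyl)sulfonyl takes the place of either (3,5-dimethylphenyl)carbonyl (a 1.6-fold lower number from compound 2 to compound 3 (0.21 log units; within the scatter)) or (3-methylphenyl)carbonyl (a 1.5-fold lower number from compound 1 to compound 3 (0.17 log units; within the scatter)), and in (this assay) both steps stay within the scatter. Among these three compounds, then, a sulfonyl link serves this position as well as a carbonyl link. No evidence at hand accounts for this result. Still open, from the compounds shown here alone, is how this nitrogen would fare carrying a group with no aromatic ring, such as a plain acetyl, or with a free amine in place of the acyl group.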